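Antiproliferative series: a furanyl group replaces a methyl

A few compounds are considered here, and "the series" means these few. Any claim that something is new, unique, unknown or untested is made for them only; others in the source may bear on it.

Measured compounds:
compound 1 `COc1ccc2nc(-c3ccc(C)o3)cc(NCc3ccc(F)cc3)c2c1`, 8300 nM
compound 2 `COc1cc2c(NCc3ccc(F)cc3)cc(C)nc2cc1OCCCN1CCCC1`, 1900 nM

The assay is a functional assay on MCF-10A cells (Homo sapiens) for antiproliferative activity, with a stated time of 48 h; on this read-out higher numbers stand for an effect only at larger amounts of compound and lower numbers for an effect already at smaller amounts. In this assay compound 1 gives 8300 nM, while compound 2 gives 1900 nM. Compound 2 thus stands at the lowest of the two numbers; its nearest neighbour is compound 1, whose number is higher by a margin beyond the usual scatter. The two compounds differ in more than one place, so their values show only the overall gap, not what any single change does.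

Compound 3 `COc1cc2c(NCc3ccc(F)cc3)cc(-c3ccc(C)o3)nc2cc1OCCCN1CCCC1` has not yet been measured. It is obtained from compound 2 by 5-methylfuran-2-yl in place of methyl on an aromatic carbon, and in compound 3 the 5-methylfuran-2-yl group and the pyrrolidinylpropoxy chain of compound 2 appear together.

Among the compounds with values here, there is no measured pair in this assay that isolates this exchange, so the size of the step is not known. The expected step of a 1.3-fold higher number from compound 2 to compound 3 (0.12 log units; within the scatter) is judged to be none beyond the scatter, in either direction. Compound 3 is therefore estimated at 2500 nM, with a range from 700 nM to 8000 nM.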

Compound 3, half-maximal effective concentration: 1800 nM
Estimate against measurement, compound 3: 1.4-fold (0.14 log units) above; the measured number falls inside the stated range.
By their numbers in this assay, from the lowest: compounds 3 and 2 (each within the scatter of the next); then compound 1.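

In this assay the aromatic carbon next to the ring nitrogen takes 5-methylfuran-2-yl in place of methyl with a 1.1-fold lower number from compound 2 to compound 3 (0.02 log units; within the scatter) and so no difference beyond the scatter, even though the group entering has six heavy atoms, a five-membered aromatic ring and a hydrogen-bond acceptor where the group leaving has one carbon. Within the data shown here, compound 3 also separates the two differences that compound 1 and compound 2 left tied together: 3-(pyrrolidin-1-yl)propoxy in place of hydrogen on an aromatic carbon gives a 4.6-fold lower number from compound 1 to compound 3 (0.66 log units; beyond the scatter) and is thus the one change of the two that shifts the number beyond the scatter, though only modestly. Nothing at hand bears on why the chain shifts the number or why the exchange at the carbon next to the ring nitrogen does not.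

The compounds shown leave open how far this position stays indifferent to its substituent, for instance with an unsubstituted furan-2-yl, a phenyl ring or an amine there. They also leave open whether the effect of the chain depends on its length or on its terminal pyrrolidine, as a shorter ethoxy link or a terminal morpholine would show.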